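Compound 2 to compound 3: hydrogen in place of chloro

The compounds below may be only part of what the source reports. "The series", "measured", "known", "first", "only" and "open" are said of these compounds alone.

These notes cover compound 1 `O=C(NCc1ccc(C(F)(F)F)cc1)N1C(=O)c2ccccc2S1(=O)=O` and compound 2 `O=C(NCc1ccccc1Cl)N1C(=O)c2ccccc2S1(=O)=O`, both read in a physicochemical assay for pharmacokinetics; on this read-out higher numbers stand for a longer-lived compound and lower numbers for a shorter-lived compound. Compound 1 gives > 166 h, which is a limit of the assay and not a number. Compound 2 gives > 166 h, which is also a limit and not a number. The evidence across the two readings is the limit of > 166 h in this assay, at which 2 of the 2 values shown sit. Going by the values given here, the standing of compound 2 is therefore known only as a limit, and no step between measured compounds is available.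

The unmeasured compound 3 `O=C(NCc1ccccc1)N1C(=O)c2ccccc2S1(=O)=O` differs from compound 2 by hydrogen in place of chloro on an aromatic carbon. The change is hydrogen in place of chloro on an aromatic carbon, or 2-chlorophenyl to phenyl.

In this assay no step beyond the scatter is expected, in either direction. This expectation rests on compound 2 and its limit of > 166 h. The expected change, a step that the limit leaves unreadable from compound 2 to compound 3, is an estimate and stays within the scatter. A report of compound 3 as a limit is also the likely outcome. For compound 3 the estimated value is 180 h, with an expected range of 100 h to 350 h.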

Compound 3, half-life: > 166 h
Compound 3: a limit, no number; the forecaster's own chance of this, stated with the estimate: 80%; the middle value is on the limit's open side.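

In this assay compound 3 gives > 166 h, which is a limit of the assay and not a number. No step from compound 1 or compound 2 to compound 3 can be read, because all the readings sit at one limit: the limit of > 166 h in this assay, at which 3 of the 3 values shown sit.

The compounds shown leave open whether hydrogen, chloro or trifluoromethyl on the aromatic carbon makes any difference in this assay, as none of the three has a number.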